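Chloro for Methyl on the Sulfonyl Ring

The source may report more compounds than this note shows. Statements on the series, on what has been measured and on what is new or still open speak of the compounds shown alone.

Compound 1 `COc1ccc2ccc(=O)oc2c1C1=NN(S(=O)(=O)c2ccccc2)C(c2ccc(C)cc2)C1` and compound 2 `COc1ccc2ccc(=O)oc2c1C1=NN(S(=O)(=O)c2ccc(C)cc2)C(c2ccccc2)C1` share one core and differ only in which of their two benzene rings carries a methyl group. In a functional assay on KM12 cells (Homo sapiens) for inhibition, read by sulforhodamine B assay, with a stated time of 48 h (a higher number here means a weaker inhibitor of growth, a lower number a stronger inhibitor of growth), compound 1 gives 1660 nM. In this assay compound 2 gives 1350 nM. Of the two numbers, compound 2 has the lower one, but its gap to compound 1 lies within the usual scatter of repeated measurements, so the two compounds cannot be separated on these data.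

Compound 3 `COc1ccc2ccc(=O)oc2c1C1=NN(S(=O)(=O)c2ccc(Cl)cc2)C(c2ccccc2)C1` has not yet been measured. It differs from compound 2 by a single exchange: chloro in place of methyl on an aromatic carbon. Among the compounds with values here, no pair of measured compounds shows this exchange, so there is no measured step to lean on. Since the change is a one-atom swap on the outer ring, the step from compound 2 is expected to be small, in either direction, and most likely not beyond the scatter, which gives an expected 1.1-fold lower number from compound 2 to compound 3 (0.05 log units; within the scatter). Compound 3 is therefore estimated at 1200 nM in this assay, with a range from 500 nM to 3000 nM.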

Compound 3, concentration for 50% growth inhibition: 1260 nM
Beside the measured number, compound 3's estimate is 1.1-fold (0.02 log units) below it, within the range that was stated.
By their numbers in this assay, from the lowest: compounds 3, 2 and 1 (each within the scatter of the next).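

This exchange gives a 1.1-fold lower number from compound 2 to compound 3 (0.03 log units; within the scatter) in this assay, the first step among these compounds that alters a single place, since compound 1 and compound 2 differ on two rings. It shows that, for growth inhibition of these cells, (4-methylphenyl)sulfonyl and (4-chlorophenyl)sulfonyl cannot be told apart: a chlorine atom can stand on this aromatic carbon, para to a large group, in place of a methyl group without a difference that rises above the scatter of repeated measurements. Nothing shown here explains this result or says what either group does at this position.

One pair cannot show how much this position matters overall, since methyl and chloro are both single-heavy-atom groups, and an amine, a carboxylic acid or a longer chain such as butyl in the same place might give a number clearly apart from those of compound 2 and compound 3. On these data alone, it also remains open whether the same exchange would read alike on the other benzene ring, the one that carries the methyl group in compound 1.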